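The compounds below may be only part of what the source reports. "The series", "measured", "known", "first", "only" and "open" are said of these compounds alone.

Measured so far: compound 1 `CN1CCc2nc(C#Cc3cccc(F)c3)sc2C1`, compound 2 `CC(C)CN1CCc2nc(C#Cc3ccccc3)sc2C1` and compound 3 `Fc1cccc(C#Cc2nc3c(s2)CN(C2CCOC2)CC3)c1`.

In an assay on HEK293 cells for negative allosteric modulation of metabotropic glutamate receptor 5 (Homo sapiens), read by FLIPR, with a stated time of 1 h (a lower number here means a stronger inhibitor, a higher number a weaker inhibitor), compound 2 gives 650 nM, and compound 3 gives 400 nM. Compound 1 gives only a limit of this assay, > 10000 nM, the point at which one of the three values sits (the limit of > 10000 nM in this assay, at which 1 of the 3 values shown sits). Compound 2 and compound 3 lie within the usual scatter of each other, so the two numbers cannot be ranked.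

Compound 4 `O=S(=O)(C1CC1)N1CCc2nc(C#Cc3ccccc3)sc2C1` has not yet been measured. It differs from compound 2 in one place: cyclopropylsulfonyl in place of isobutyl on an amine nitrogen in a ring. Within the data shown here, the only measured step at that same nitrogen, an at least 25-fold lower number from compound 1 to compound 3 (1.39 log units; beyond the scatter), was large, but it concerned different groups and so guides only loosely. A step of a 1.4-fold lower number from compound 2 to compound 4 (0.16 log units; within the scatter) is expected in this assay, which is within the scatter. Compound 4 is therefore estimated at 450 nM, in a range from 100 nM to 2500 nM.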

Compound 4, half-maximal inhibitory concentration: 34 nM
For compound 4 the middle estimate is 13-fold (1.12 log units) above the measured one, and the stated range ends above it.
By their numbers in this assay, from the lowest: compound 4; then compounds 3 and 2 (each within the scatter of the next). At a limit, above all of these: compound 1.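

Replacing isobutyl with cyclopropylsulfonyl on this amine nitrogen gives, in this assay, a 19-fold lower number from compound 2 to compound 4 (1.28 log units; beyond the scatter), so this position accepts a group with sulfur and oxygen and 2 hydrogen-bond acceptors, where isobutyl has none. Unlike the earlier step at this nitrogen, which started from a limit, this step joins two exact numbers and so has a definite size. No measurement shown accounts for the change.

Going by these compounds, whether the sulfonyl or the cyclopropyl matters more remains open, and a methylsulfonyl group would help separate them. An acetyl amide on the same nitrogen would test whether a sulfonyl is needed at all.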